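A methyl in place of fluoro on the sulfonyl phenyl

The compounds below may be only part of what the source reports. "The series", "measured", "known", "first", "only" and "open" are said of these compounds alone.

Compound 1 `COc1ccc(-c2cc(=O)c3c(OC)cc(OC)cc3[nH]2)cc1`: in a functional assay on HepG2 cells (Homo sapiens) for antiproliferative activity, with a stated time of 72 h (a lower number here means that less compound is needed, a higher number that more compound is needed for the effect), compound 1 gives > 31100 nM, which is a limit of the assay and not a number.
Compound 2 `COc1ccc(-c2cc(=O)c3c(OC)cc(OC)cc3n2S(=O)(=O)c2ccc(C#N)cc2)cc1`: in this assay compound 2 gives > 17200 nM, again a limit.
Compound 3 `COc1ccc(-c2cc(=O)c3c(OC)cc(OC)cc3n2S(=O)(=O)c2ccc(F)cc2)cc1`: in this assay compound 3 gives > 65500 nM, also a limit.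

Compound 3 therefore stands at a limit, and the two further values shown are limits as well: the limit of > 17200 nM in this assay, at which 1 of the 3 values shown sits, the limit of > 31100 nM in this assay, at which 1 of the 3 values shown sits, and the limit of > 65500 nM in this assay, at which 1 of the 3 values shown sits, are all that the three compounds offer. The step to the new compound 4 `COc1ccc(-c2cc(=O)c3c(OC)cc(OC)cc3n2S(=O)(=O)c2ccc(C)cc2)cc1` is methyl in place of fluoro on an aromatic carbon, the place being para to a large group on the phenyl carried by the sulfonyl. The measured steps that bear on it are a step that the two limits leave unreadable from compound 2 to compound 3, a step that the two limits leave unreadable from compound 1 to compound 3 and a step that the two limits leave unreadable from compound 1 to compound 2; none of them has a readable size, so no direction and no size beyond the scatter can be expected for an at least 1.3-fold lower number from compound 3 to compound 4 (0.11 log units; that floor lies within the scatter), and that step is only an estimate. Compound 4 is accordingly expected to give about 50000 nM, within 15000 nM to 200000 nM, most likely again as a limit.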

Compound 4, half-maximal effective concentration: > 44800 nM
Compound 4 ended at the assay's limit; the forecaster's own chance of this, stated with the estimate: 80%; the middle value does not contradict the limit.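

Compound 4, like compound 1, compound 2 and compound 3, stands only at a limit of the assay, so the steps from each of them to compound 4 cannot be read. The compounds shown leave open whether any sulfonyl group shown, or any change on its phenyl, alters the result in this assay.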